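Cytotoxicity of quinoline ureas: a bromophenyl semicarbazide analogue

The source may hold more compounds than are shown below. What is called first, only, known or untested is meant among the compounds shown, and "the series" means these compounds.

Compound 1 (`COc1cc(NC(C)CCCNC(=O)NC2CCCCC2)c2ncccc2c1`) carries a cyclohexyl urea on the chain attached to its shared core; in an ADME assay on L6 cells (Rattus norvegicus) for cytotoxicity, read by resazurin assay, with a stated time of 70 h (a lower number here means a stronger inhibitor, a higher number a weaker inhibitor), compound 1 has "not determined" (no result reported), so it stands without a number. Two relatives have been tested. Compound 2 (`COc1cc(NC(C)CCCNC(=O)NCCNC(c2ccccc2)(c2ccccc2)c2ccccc2)c2ncccc2c1`) gives only a limit, > 171000 nM, in this assay. Compound 3 (`COc1ccc(/C(=N/NC(=O)NCCCC(C)Nc2cc(OC)cc3cccnc23)c2ccccc2)cc1`) likewise gives only a limit, > 195000 nM, in this assay. Both results thus sit at the edge of what the method reports, as the limit of > 171000 nM in this assay, at which 1 of the 3 values shown sits, and the limit of > 195000 nM in this assay, at which 1 of the 3 values shown sits, show. Compound 4 (`COc1cc(NC(C)CCCNC(=O)NNC(=O)Nc2ccc(Br)cc2)c2ncccc2c1`) differs from compound 1 by ((4-bromophenyl)carbamoyl)amino in place of cyclohexyl on an amide-type nitrogen. Within the data shown here, no measured step frames this change, so no direction beyond the usual scatter is expected. Compound 4 is expected to show weak cytotoxicity, estimated at 150000 nM, within 50000 nM to 300000 nM.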

Compound 4, half-maximal inhibitory concentration: 38700 nM
For compound 4 the middle estimate is 3.9-fold (0.59 log units) above the measured one, outside the stated range (below it).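

No step can be read between compound 1 and compound 4, as compound 1 has no number in this assay. The compounds shown leave open what replacing cyclohexyl with ((4-bromophenyl)carbamoyl)amino does to the value.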